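The source may hold more compounds than are shown below. What is called first, only, known or untested is meant among the compounds shown, and "the series" means these compounds.

Measured in a functional assay on A2780 cells (Homo sapiens) for antiproliferative activity, read by fluorescence, with a stated time of 72 h; a lower number here means a stronger inhibitor, a higher number a weaker inhibitor:
- compound 1 (`CN1CCC(C(=O)N2Cc3c(NC(=O)c4ccsc4)n[nH]c3C2(C)C)CC1`) gives 140 nM
- compound 2 (`CN1CCC(C(=O)N2Cc3c(NC(=O)c4ccc(C(F)(F)F)cc4)n[nH]c3C2(C)C)CC1`) gives 60 nM

Within the data shown here, compound 2 holds the lower of the two numbers, and compound 1 is its only measured neighbour. Compound 3 (`CN1CCC(C(=O)N2Cc3c(NC(=O)c4ccccc4)n[nH]c3C2(C)C)CC1`) is not yet measured. It differs from compound 2 by hydrogen in place of trifluoromethyl on an aromatic carbon (hydrogen in place of trifluoromethyl on an aromatic carbon, para to a large group, leaving phenyl). Among the measured compounds shown here, one measured step bears on this change, a 2.3-fold lower number from compound 1 to compound 2 (0.37 log units; beyond the scatter), and it is modest. That step exchanges the whole group on the carbonyl carbon, so it indicates a likely size and gives no direct reading of the trifluoromethyl group alone. Going by that step, a modest change towards a higher number is expected in this assay, estimated as a 1.8-fold higher number from compound 2 to compound 3 (0.26 log units; within the scatter). For compound 3 the expected value is 110 nM, with an estimated range of 50 nM to 250 nM.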

Compound 3, half-maximal inhibitory concentration: 160 nM
Compound 3: the middle estimate sits 1.5-fold (0.16 log units) below what was measured, and the stated range covers the measured number.
By their numbers in this assay, from the lowest: compound 2; then compounds 1 and 3 (each within the scatter of the next).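

Among these compounds, removing the trifluoromethyl group alone in this assay gives a 2.7-fold higher number from compound 2 to compound 3 (0.43 log units; beyond the scatter), the first direct reading of this group on the aromatic carbon. Exchanging the whole group on the carbonyl carbon gives a 1.1-fold higher number from compound 1 to compound 3 (0.06 log units; within the scatter), so phenyl and thiophen-3-yl are not separated, and among these three compounds only the one carrying trifluoromethyl stands apart. No measurement on hand bears on why the number moves with this change.

On these data alone, whether a chlorine atom, a methoxy group or an amine on the same aromatic carbon would give a number close to that of compound 2 remains open. Also open, as far as these compounds go, is whether the trifluoromethyl step carries over to thiophen-3-yl bearing a trifluoromethyl group.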